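The source may report more compounds than this note shows. Statements on the series, on what has been measured and on what is new or still open speak of the compounds shown alone.

Within the data shown here, in a functional assay on KYSE-450 cells (Homo sapiens) for inhibition, read by CCK-8 assay, with a stated time of 48 h (on this read-out lower numbers stand for stronger inhibition and higher numbers for weaker inhibition), compound 3 (`COc1ccc(CN(C(=O)CSC(=S)N2CCCC2)c2cc(OC)c(OC)c(OC)c2)cc1`) gives 13800 nM, the highest of the three numbers so far. Compound 1 (`COc1ccc(CN(C(=O)CSc2nc3ccccc3o2)c2cc(OC)c(OC)c(OC)c2)cc1`) gives 840 nM and compound 2 (`COc1ccc(CN(C(=O)CSC(=S)N2CCN(C(C)=O)CC2)c2cc(OC)c(OC)c(OC)c2)cc1`) gives 370 nM. Compound 4 (`COc1ccc(CN(C(=O)CN2CCN(C(C)=O)CC2)c2cc(OC)c(OC)c(OC)c2)cc1`) has not yet been measured. Its change from compound 3 is a group of 9 heavy atoms (6 carbon, 2 nitrogen, 1 oxygen; one six-membered non-aromatic ring with 2 hetero atoms) in place of a group of 8 heavy atoms (5 carbon, 1 nitrogen, 2 sulfur; one five-membered non-aromatic ring with 1 hetero atom), on a saturated chain carbon bound to a carbonyl carbon. The entering 4-acetylpiperazin-1-yl also occurs in compound 2, but there it stands on a thiocarbonyl carbon, whereas in compound 4 it stands on a saturated chain carbon bound to a carbonyl carbon. The closest evidence is the large step of a 37-fold higher number from compound 2 to compound 3 (1.57 log units; beyond the scatter), with pyrrolidin-1-yl in place of 4-acetylpiperazin-1-yl on a thiocarbonyl carbon. The large step of a 16-fold higher number from compound 1 to compound 3 (1.22 log units; beyond the scatter) and the modest step of a 2.3-fold lower number from compound 1 to compound 2 (0.36 log units; beyond the scatter) show that the group on the sulfur matters in this series, but neither tests a group placed directly on the chain carbon. Among the measured compounds shown here, no measured compound carries one there, so only part of the step of a 37-fold higher number from compound 2 to compound 3 (1.57 log units; beyond the scatter) is expected to carry over. A substantial fall in the number is therefore expected in this assay, smaller than that step. The expected size is a 9.2-fold lower number from compound 3 to compound 4 (0.96 log units; beyond the scatter). Compound 4 is estimated at 1500 nM, with an expected range of 300 nM to 8000 nM.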

Compound 4, half-maximal inhibitory concentration: 10800 nM
For compound 4 the middle estimate is 7.2-fold (0.86 log units) below the measured one; measured number above the stated range.
By their numbers in this assay, from the lowest: compound 2; then compound 1; then compounds 4 and 3 (each within the scatter of the next).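

In this assay, 4-acetylpiperazin-1-yl placed directly on a saturated chain carbon bound to a carbonyl carbon does not keep the reading it gives on a thiocarbonyl carbon (a 29-fold higher number from compound 2 to compound 4 (1.47 log units; beyond the scatter)), so in these compounds its low number goes with the sulfur and thiocarbonyl link of compound 2, not with the group alone. The change also separates it from (1,3-benzoxazol-2-yl)sulfanyl at the same place (a 13-fold higher number from compound 1 to compound 4 (1.11 log units; beyond the scatter)), while the exchange of the group carrying pyrrolidin-1-yl for 4-acetylpiperazin-1-yl gives no separation (a 1.3-fold lower number from compound 3 to compound 4 (0.11 log units; within the scatter)), which leaves two quite different groups at the same level. No measurement of any property of these compounds is available to account for this result.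

The compounds shown do not separate the contribution of the sulfur from that of the thiocarbonyl carbon in the link of compound 2. Also open, as far as these compounds go, is how pyrrolidin-1-yl, morpholin-4-yl or a primary amine would read directly on the chain carbon, and whether 4-acetylpiperazin-1-yl regains its low number when joined through a longer carbon chain.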